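A few compounds are considered here, and "the series" means these few. Any claim that something is new, unique, unknown or untested is made for them only; others in the source may bear on it.

Three compounds share one core and carry an aryl acid on an oxygen on a saturated carbon. Compound 1 `Cc1c(OCCCCOc2ccccc2C(=O)O)ccc(C(=O)CC(C)C)c1O` gives 28.1% in an assay on HEK293 cells for positive allosteric modulation of metabotropic glutamate receptor 3 (Rattus norvegicus), read by thallium flux, with a stated time of 2.5 min; on this read-out higher numbers stand for larger maximal responses and lower numbers for smaller maximal responses. Compound 2 `Cc1c(OCCCCOc2ccc(C(=O)O)c(Cl)c2)ccc(C(=O)CC(C)C)c1O` gives 49.5%, and compound 3 `Cc1c(OCCCCOc2ccc(C(=O)O)cc2)ccc(C(=O)CC(C)C)c1O` gives 51.9%. The step of a number 21.4 percentage points higher from compound 1 to compound 2 (beyond the scatter) and the step of a number 23.8 percentage points higher from compound 1 to compound 3 (beyond the scatter) both lie beyond the scatter, whereas the step of a number 2.4 percentage points higher from compound 2 to compound 3 (within the scatter) lies within it. Compound 3 thus shows the highest of the three numbers, but its separation from compound 2 is within the scatter, and only its distance from compound 1 is beyond it.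

Compound 4 `Cc1c(OCCCCOc2ccc(C(=O)O)cc2)ccc(C(=O)CC2CCCC2)c1O` differs from compound 3 at a different place in the structure: cyclopentyl in place of isopropyl on a saturated chain carbon bound to a carbonyl carbon. Within the data shown here, none of the measured steps concern this part of the molecule; all three involve the aryl acid or its chloro substituent. Among the measured compounds shown here, no measured step therefore bears directly on the change, and the data give no direction for it. The step of a number 0.1 percentage points higher from compound 3 to compound 4 (within the scatter) is expected to remain within the scatter. In this assay compound 4 is estimated at 52%, with a range from 38% to 66%.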

Compound 4, largest response reached (reported as percent of maximum), in percent of the reference or control that the assay uses: 26.7%
Compound 4: middle estimate off by 25.3 percentage points, on the high side; the measured number lies below the stated range.
By their numbers in this assay, from the lowest: compounds 4 and 1 (each within the scatter of the next); then compounds 2 and 3 (each within the scatter of the next).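

Among these compounds, replacing isopropyl with cyclopentyl on a saturated chain carbon bound to a carbonyl carbon gives a number 25.2 percentage points lower from compound 3 to compound 4 (beyond the scatter) in this assay and so shows that this end of the molecule, unchanged among the earlier compounds, also bears on the maximal response. Like a number 23.8 percentage points higher from compound 1 to compound 3 (beyond the scatter) on the aryl acid, this step lies beyond the scatter, so the response does not depend on the aryl acid alone, and the larger carbon ring does not keep the number of compound 3 at this place. Nothing available explains why this change lowers the number.

The compounds shown leave open whether a cyclobutyl group or a straight propyl chain at this place would keep the number of compound 3 or lower it as cyclopentyl does, and therefore whether the ring itself or the count of carbons goes with the drop. They also leave open whether cyclopentyl would lower the number to the same extent alongside the 2-carboxyphenyl or 4-carboxy-3-chlorophenyl group.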